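Working notes: from compound 2 to compound 3

This account rests on a few compounds, and the source may have more. Where it says the series, first, only, none or still open, it means among the compounds named here.

Compound 2 `COc1cc2c(Nc3ccc(OCc4cccc(F)c4)c(Cl)c3)ncnc2cc1OCCCCCCn1ccnc1[N+](=O)[O-]` gives > 50000 nM in a functional assay on HT-29 cells (Homo sapiens) for inhibition, read by sulforhodamine B assay, with a stated time of 72 h (on this read-out higher numbers stand for weaker inhibition and lower numbers for stronger inhibition), and this is a limit of the assay, not a number. Among the measured compounds shown here, its only measured neighbour is compound 1 `COc1cc2c(Nc3ccc(OCc4cccc(F)c4)c(Cl)c3)ncnc2cc1OCCCCCn1ccnc1[N+](=O)[O-]`, which gives 14100 nM in this assay. The step between them, an at least 3.5-fold higher number from compound 1 to compound 2 (0.54 log units; beyond the scatter), came with (2-nitro-1H-imidazol-1-yl)methyl in place of 2-nitro-1H-imidazol-1-yl on a saturated chain carbon. For the measured compounds named here, it lies beyond the scatter, it is the only step that bears here, and its full size is unknown.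

Compound 3 `COc1cc2c(Nc3ccc(OCc4cccc(F)c4)c(Cl)c3)ncnc2cc1OCCOCCn1ccnc1[N+](=O)[O-]` carries 2-(2-nitro-1H-imidazol-1-yl)ethoxy in place of 4-(2-nitro-1H-imidazol-1-yl)butyl on a saturated chain carbon, two bonds along the chain from an oxygen on an aromatic ring. Going by the values given here, no measured step tests an oxygen in the chain, so the basis is thin. The entering group is the smaller by heavy atoms, so a move back toward compound 1 and its 14100 nM is expected, meaning a lower number in this assay. Another limit remains possible for compound 3. The expected step is an at least 2.5-fold lower number from compound 2 to compound 3 (0.39 log units; beyond the scatter). Compound 3 is estimated at 20000 nM, with an expected range of 7000 nM to 50000 nM.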

Compound 3, half-maximal inhibitory concentration: 7640 nM
Compound 3: the middle estimate sits 2.6-fold (0.42 log units) above what was measured, within the range that was stated.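

In this assay, 2-(2-nitro-1H-imidazol-1-yl)ethoxy in place of 4-(2-nitro-1H-imidazol-1-yl)butyl on a saturated chain carbon gives an at least 6.5-fold lower number from compound 2 to compound 3 (0.81 log units; beyond the scatter), which shows that a chain at this position carrying an oxygen can return a measurable number where compound 2 does not. Against the shorter all-carbon chain, 2-(2-nitro-1H-imidazol-1-yl)ethoxy in place of 3-(2-nitro-1H-imidazol-1-yl)propyl gives a 1.8-fold lower number from compound 1 to compound 3 (0.27 log units; within the scatter), so this change cannot be separated from the scatter and compound 3 stands level with compound 1 rather than with compound 2. The first of these steps has no upper size and only a lower bound because compound 2 is held at a limit of the assay: the limit of > 50000 nM in this assay, at which 1 of the 3 values shown sits.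

Going by these compounds, whether an amine in place of the chain oxygen, or a longer chain carrying the same oxygen, would stay level with compound 3 or reach the limit of compound 2 remains open. Also open, on these data alone, is what a plain imidazole or a morpholine at the chain end, in place of 2-nitro-1H-imidazol-1-yl, would give on the same core.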